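This account rests on a few compounds, and the source may have more. Where it says the series, first, only, none or still open, it means among the compounds named here.

Working notes on the cytotoxicity series.

Going by the values given here, compound 2 `COc1ccc(C(=O)/C=C/c2cc(-c3cc(OC)c(OC)c(OC)c3)n[nH]2)cc1OC` is one of two compounds measured in a functional assay on U-251 cells (Homo sapiens) for cytotoxicity, read by sulforhodamine B assay, with a stated time of 48 h, tested at 10 uM; a higher number here means a weaker effect of the compound at the concentration tested, a lower number a stronger effect; compound 2 gives -100%. Among the compounds with values here, the only comparator is compound 1 `COc1cc(-c2cc(/C=C/C(=O)c3ccc(N)cc3)[nH]n2)cc(OC)c1OC`, which in this assay gives -96%; the two values lie within the scatter of each other, so neither can be called the stronger on these numbers. Within the data shown here, the single known step, a number 4 percentage points lower from compound 1 to compound 2 (within the scatter), exchanges the whole aryl group on the carbonyl carbon and yet leaves the read-out essentially where it was, close to the floor of the measurement.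

Compound 3 `COc1ccc(C(=O)/C=C/c2cc(-c3cc(OC)c(OC)c(OC)c3)n[nH]2)cc1` is the next member. Compared with compound 2 the change is hydrogen in place of methoxy on an aromatic carbon, sitting on an aromatic carbon of the six-membered carbon-only ring, ortho to a methoxy group and meta to a large group. Among the measured compounds shown here, no measured step matches this change; the step from compound 1 to compound 2 touches the same ring but swaps it entirely, and it stays within the scatter. At this concentration the read-out of the pair is already near its floor, which leaves little room for movement downward.

The estimate for compound 3 in this assay is therefore -92%, with a range from -100% to -70%. The step this estimate implies, a number 8 percentage points higher from compound 2 to compound 3 (within the scatter), is expected to stay within the scatter, and a weaker response would be the only direction with room to show.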

Compound 3, a percentage reported as activity, at one concentration (the size of the read-out at that concentration, not a potency): -98%
Estimate against measurement, compound 3: 6 percentage points above; the range from low to high includes it.
By their numbers in this assay, from the lowest: compounds 2, 3 and 1 (each within the scatter of the next).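

In this assay the step of a number 2 percentage points higher from compound 2 to compound 3 (within the scatter) goes with the change from 3,4-dimethoxyphenyl to 4-methoxyphenyl, so at this position, ortho to a methoxy group and meta to a large group, no difference between hydrogen and methoxy can be read at this concentration. The step of a number 2 percentage points lower from compound 1 to compound 3 (within the scatter) adds a second exchange of a single group on the same ring, methoxy in place of amino on an aromatic carbon, where the earlier step had replaced the whole aryl group, and this exchange too leaves no readable difference. Nothing available explains why the read-out stays in place across these changes.

All three values lie close to the floor of the read-out at a single concentration, so a stronger or weaker effect of one compound compared with another could remain hidden at that concentration. Going by these compounds, it stays open whether the ring would give the same read-out with a hydroxyl group, a chlorine atom or a carboxylic acid in place of the methoxy group, or with hydrogen alone at that carbon.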